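From Selenium to Sulfur: Compound 2 to Compound 4

A few compounds are considered here, and "the series" means these few. Any claim that something is new, unique, unknown or untested is made for them only; others in the source may bear on it.

Measured in a functional assay on MCF7 cells (Homo sapiens) for cytotoxicity, read by MTT assay, with a stated time of 72 h; a lower number here means a stronger inhibitor of growth, a higher number a weaker inhibitor of growth:
Compound 1 `CS/C(=N\C(=O)c1ccno1)NC(=O)c1ccno1` gives > 100000 nM, a limit of the assay rather than a number.
Compound 2 `C[Se]/C(=N\C(=O)c1ccco1)NC(=O)c1ccco1` gives 88900 nM.
Compound 3 `CS/C(=N\C(=O)c1cc2ccccc2s1)NC(=O)c1cc2ccccc2s1` gives 43400 nM.

Of the two numbers, compound 2 holds the higher and compound 3 the lower, a gap beyond the scatter. Compound 4 `CS/C(=N\C(=O)c1ccco1)NC(=O)c1ccco1` is not yet measured. It differs from compound 2 by a group of 2 heavy atoms (1 carbon, 1 sulfur; no ring) in place of a group of 2 heavy atoms (1 carbon, 1 selenium; no ring), on a carbon with a double bond to nitrogen. Within the data shown here, no measured pair shows this change, so in this assay the expected step is a 1.0-fold higher number from compound 2 to compound 4 (0.01 log units; within the scatter), nothing beyond the scatter. Compound 4 is therefore estimated at 90000 nM, between 40000 nM and 200000 nM.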

Compound 4, concentration for total growth inhibition: > 100000 nM
Compound 4 ended at the assay's limit; the forecaster's own chance of this, stated with the estimate: 45%; at least 1.1-fold (0.04 log units) between middle value and limit.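

In this assay compound 4 gives > 100000 nM, which is a limit of the assay and not a number. Among these compounds, this is the first reading of a change at this position: methylsulfanyl in place of the selenium-bearing group, on a carbon with a double bond to nitrogen, gives an at least 1.1-fold higher number from compound 2 to compound 4 (0.05 log units; that floor lies within the scatter). The true size of this step stays unread because it rests on a limit: the limit of > 100000 nM in this assay, at which 2 of the 4 values shown sit.

Still open, from the compounds shown here alone, is whether the same exchange would give a readable step on the core of compound 3. Also open, going by these compounds, is what an amine or a longer chain would give on this carbon.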